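Nitro for hydroxy on two related benzothiazole anilines

The source may report more compounds than this note shows. Statements on the series, on what has been measured and on what is new or still open speak of the compounds shown alone.

The three measured compounds, in a functional assay on A549 cells (Homo sapiens) for antiproliferative activity, read by sulforhodamine B assay, with a stated time of 48 h; a higher number here means a weaker inhibitor, a lower number a stronger inhibitor:
compound 1, `COc1ccc(C(=O)/C=C\Nc2ccc(-c3nc4cc(OC)c(OC)c(OC)c4s3)cc2C)cc1O`, gives 15400 nM;
compound 2, `COc1cc(OC)c2sc(-c3ccc(N/C=C\C(=O)c4ccc(OC)c(O)c4)cc3)nc2c1`, gives 10600 nM;
compound 3, `COc1ccc(C(=O)/C=C\Nc2ccc(-c3nc4cc(OC)c(OC)c(OC)c4s3)cc2C)cc1[N+](=O)[O-]`, gives 9100 nM.

Compound 1 and compound 3 differ in one place only. The change is nitro in place of hydroxy on an aromatic carbon. The step that goes with it is a 1.7-fold lower number from compound 1 to compound 3 (0.23 log units; within the scatter), so the two compounds cannot be told apart by this assay. Compound 2 carries the same 3-hydroxy-4-methoxyphenyl end as compound 1 on a different core; how the two cores differ is not broken down here, and the values of compound 1 and compound 2 lie within the scatter of each other.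

Compound 4, `COc1cc(OC)c2sc(-c3ccc(N/C=C\C(=O)c4ccc(OC)c([N+](=O)[O-])c4)cc3)nc2c1`, has not been measured in this assay. It arises from compound 2 by nitro in place of hydroxy on an aromatic carbon. The surroundings of the change are described in the same words for both pairs, so this is the same change that was made from compound 1 to compound 3. Among the measured compounds shown here, for compound 4 the expected step is a 1.5-fold lower number from compound 2 to compound 4 (0.18 log units; within the scatter), placed beside the earlier one because a 1.7-fold lower number from compound 1 to compound 3 (0.23 log units; within the scatter) is the only measured instance of this change and lies within the scatter. On that single precedent, compound 4 is estimated at 7000 nM, with a range from 3000 nM to 18000 nM expected to hold most repeat measurements.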

Compound 4, half-maximal inhibitory concentration: 5800 nM
Compound 4: the middle estimate sits 1.2-fold (0.08 log units) above what was measured; the range from low to high includes it.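

In this assay, nitro in place of hydroxy on an aromatic carbon goes with a 1.8-fold lower number from compound 2 to compound 4 (0.26 log units; within the scatter), a step too small for the two compounds to be told apart in this measurement. Set beside the earlier pair, the same change reads alike on the two cores: the same change on two cores in this assay, a 1.7-fold lower number (0.23 log units; within the scatter) from compound 1 to compound 3 and a 1.8-fold lower number (0.26 log units; within the scatter) from compound 2 to compound 4, 1.1-fold (0.03 log units) apart, within the scatter of two such steps This shows that, in these two pairs, the step carried from one core to the other with no detectable difference in its size, but it does not show that the change itself does anything to the antiproliferative read-out, as each step on its own lies within the scatter, and two pairs say nothing about any other core in the series.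

The compounds shown leave open whether another group at this place on the aromatic ring, such as an amine, a carboxylic acid or a fluorine, would give a step that lies beyond the scatter. Also open, on these data alone, is how the same change would read if the methoxy group to which it stands ortho were replaced by a longer chain such as ethoxy.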